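From compound 2 to compound 3: a new phenyl group

This account rests on a few compounds, and the source may have more. Where it says the series, first, only, none or still open, it means among the compounds named here.

Compound 1 `CC1=C(c2ccc(F)cc2)C(c2ccc(OC[C@H](C)N3CC[C@@H](C)C3)cc2)Oc2ccc(O)cc21`: 2000 ng.h/mL
Compound 2 `CC1=C(c2cccc(F)c2)C(c2ccc(OC[C@H](C)N3CC[C@@H](C)C3)cc2)Oc2ccc(O)cc21`: 350 ng.h/mL

Among the compounds with values here, in an ADME assay on the whole organism for pharmacokinetics, with Mus musculus as the target, at a dose of 10 mg/kg by the oral route (a lower number here means less compound in the circulation, a higher number more compound in the circulation at the dose given), compound 2 has the lower of the two numbers measured so far. The next compound, compound 3 `CC1=C(c2ccc(O)cc2)C(c2ccc(OC[C@H](C)N3CC[C@@H](C)C3)cc2)Oc2ccc(O)cc21`, has 4-hydroxyphenyl in place of 3-fluorophenyl on a double-bonded ring carbon. Within the data shown here, only one measured step involves this same place: a 5.7-fold lower number from compound 1 to compound 2 (0.76 log units; beyond the scatter). That step lies beyond the scatter, so a change here can clearly matter in this assay. However, it swaps one fluorophenyl for another, and no measured compound yet shows what 4-hydroxyphenyl does, so the direction stays open. The best guess is therefore no step beyond the scatter, with wide uncertainty either way. The estimate is an expected 1.2-fold lower number from compound 2 to compound 3 (0.07 log units; within the scatter). The estimated value for compound 3 is 300 ng.h/mL, with an expected range of 70 ng.h/mL to 1200 ng.h/mL.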

Compound 3, area under the concentration-time curve: 460 ng.h/mL
Estimate against measurement, compound 3: 1.5-fold (0.19 log units) below, within the range that was stated.
By their numbers in this assay, from the lowest: compounds 2 and 3 (each within the scatter of the next); then compound 1.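

In this assay, the change from 3-fluorophenyl to 4-hydroxyphenyl gives a 1.3-fold higher number from compound 2 to compound 3 (0.12 log units; within the scatter), so this swap, which adds a hydrogen-bond donor, leaves the number within the scatter. Replacing fluoro with hydroxy on the same aromatic carbon gives a 4.3-fold lower number from compound 1 to compound 3 (0.64 log units; beyond the scatter), the first view of what a different group does there rather than a moved fluoro. Among these three compounds, compound 1 with its 4-fluorophenyl group therefore stands alone at the top, while both alternatives sit together lower down, and nothing measured here explains why.

On these data alone, whether that higher number needs fluoro in particular remains open, and 4-chlorophenyl or 4-methoxyphenyl at this place would test it. 3-Hydroxyphenyl would show whether hydroxy, like fluoro, gives a different number at the other ring position.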